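The source may hold more compounds than are shown below. What is called first, only, known or untested is meant among the compounds shown, and "the series" means these compounds.

In an ADME assay, in phosphate buffer, at 28 degrees C, at pH 7.0 (on this read-out lower numbers stand for a shorter-lived compound and higher numbers for a longer-lived compound), compound 1 `C[C@@H](O)[C@H]1C(=O)N2C(C(=O)O)=C(C(C)(C)C)O[C@H]12` gives 8.1 h, compound 2 `COC(=O)[C@@H](O)[C@H]1C(=O)N2C(C(=O)O)=C(C(C)(C)C)O[C@H]12` gives 6.2 h and compound 3 `COC(=O)[C@H](O)[C@H]1C(=O)N2C(C(=O)O)=C(C(C)(C)C)O[C@H]12` gives 6.7 h, so compound 3 stands level with the other two within the usual scatter. Compound 4 `CC(C)(C)C1=C(C(=O)O)N2C(=O)[C@H]([C@@H](O)CCc3ccccc3)[C@H]2O1` carries phenethyl in place of methoxycarbonyl on a saturated chain carbon bound to an oxygen on a saturated carbon and a saturated ring carbon. Earlier changes at this carbon gave a 1.3-fold lower number from compound 1 to compound 2 (0.12 log units; within the scatter) and a 1.2-fold lower number from compound 1 to compound 3 (0.08 log units; within the scatter), and inverting its configuration gave a 1.1-fold higher number from compound 2 to compound 3 (0.03 log units; within the scatter), all within the scatter. Among the compounds with values here, no measured compound has an aromatic ring there, so the expectation is loose. No step beyond the scatter is expected, and the estimated step is a 1.0-fold higher number from compound 3 to compound 4 (0.02 log units; within the scatter). Compound 4 is expected at 7 h, within a range of 4 h to 12 h.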

Compound 4, half-life: 39 h
Compound 4: middle estimate off by 5.6-fold (0.75 log units), on the low side; measured number outside the range, above it.
By their numbers in this assay, from the lowest: compounds 2, 3 and 1 (each within the scatter of the next); then compound 4.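

In this assay, this carbon turns out not to be indifferent to what it carries: phenethyl in place of methoxycarbonyl gives a 5.8-fold higher number from compound 3 to compound 4 (0.76 log units; beyond the scatter). Within the data shown here, every earlier change here stayed within the scatter, so this is the first step at this position that goes beyond it. Nothing measured on these compounds says why the number moves.

The compounds shown leave open whether the aromatic ring or the chain itself carries the step, which a cyclohexylethyl or a benzyl group would help to separate. Also open, going by these compounds, is whether inverting this carbon matters with phenethyl in place.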